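The source may report more compounds than this note shows. Statements on the series, on what has been measured and on what is new or still open speak of the compounds shown alone.

Measured so far:
compound 1 `O=C1O[C@@H](CO)CN1c1ccc(-n2cc(-c3ccccn3)cn2)c(F)c1` — 56400 nM
compound 2 `CCN1CCN(C[C@H]2CN(c3ccc(-n4cc(-c5ccccn5)cn4)c(F)c3)C(=O)O2)CC1` — 706000 nM

In a physicochemical assay for solubility, read by HPLC, with a stated time of 24 h (a lower number here means a less soluble compound, a higher number a more soluble compound), compound 2 stands highest of the two, its nearest neighbour being compound 1, which sits a 13-fold higher number from compound 1 to compound 2 (1.10 log units; beyond the scatter) apart. Compound 3 `COC(=O)CC1CCN(C[C@H]2CN(c3ccc(-n4cc(-c5ccccn5)cn4)c(F)c3)C(=O)O2)CC1` differs from compound 2 in one place: 4-((methoxycarbonyl)methyl)piperidin-1-yl in place of 4-ethylpiperazin-1-yl on a saturated chain carbon bound to a saturated ring carbon. Among the measured compounds shown here, only one measured step bears on this, and it replaced a hydroxy group with the 4-ethylpiperazin-1-yl group, giving a 13-fold higher number from compound 1 to compound 2 (1.10 log units; beyond the scatter); no step shows the piperazine itself being exchanged. The change is therefore expected to move this assay modestly downward, a 3.5-fold lower number from compound 2 to compound 3 (0.55 log units; beyond the scatter). Compound 3 is estimated at 200000 nM, within 50000 nM to 600000 nM.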

Compound 3, solubility: 92100 nM
For compound 3 the middle estimate is 2.2-fold (0.34 log units) above the measured one; low and high end bracket the measured number.
By their numbers in this assay, from the lowest: compounds 1 and 3 (each within the scatter of the next); then compound 2.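

In this assay, exchanging one six-membered ring group for another on this saturated chain carbon still matters: 4-((methoxycarbonyl)methyl)piperidin-1-yl in place of 4-ethylpiperazin-1-yl gives a 7.7-fold lower number from compound 2 to compound 3 (0.88 log units; beyond the scatter). Measured against hydroxy, the new group gives a 1.6-fold higher number from compound 1 to compound 3 (0.21 log units; within the scatter), so the rise seen with 4-ethylpiperazin-1-yl does not appear with every ring group at this place. No evidence here explains these differences. The compounds shown do not separate the effect of the ring from that of its side chain. As far as these compounds go, a piperidine carrying a carboxylic acid instead of the methyl ester, or a piperazine with a longer chain, remains open.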